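The source may report more compounds than this note shows. Statements on the series, on what has been measured and on what is new or still open speak of the compounds shown alone.

In a functional assay on HepG2 cells (Homo sapiens) for antiproliferative activity, read by MTT assay, with a stated time of 24 h (on this read-out higher numbers stand for weaker inhibition and lower numbers for stronger inhibition), the measured compounds are:

- compound 1 `C=CCOc1ccc2c(=O)c(-c3cc(OC)c(OC)cc3OC)coc2c1` with 3450 nM
- compound 2 `COc1cc(OC)c(-c2coc3cc(OCc4ccccc4C(F)(F)F)ccc3c2=O)cc1OC` with 6550 nM

These two values lie within the scatter of each other, so the numbers do not separate compound 2 from compound 1. Compound 3 `COc1cc(OC)c(-c2coc3cc(OCc4cccc(F)c4)ccc3c2=O)cc1OC` has not yet been measured. It carries 3-fluorophenyl in place of the 2-(trifluoromethyl)phenyl of compound 2 on a saturated chain carbon bound to an oxygen on an aromatic ring (3-fluorophenyl in place of 2-(trifluoromethyl)phenyl on a saturated chain carbon bound to an oxygen on an aromatic ring). Within the data shown here, only one measured step bears on this place, namely a 1.9-fold higher number from compound 1 to compound 2 (0.28 log units; within the scatter) as vinyl gave way to 2-(trifluoromethyl)phenyl. With a single step of that size to go on, no change beyond the scatter is expected in this assay and no direction can be firmly expected. The estimated change is a 1.3-fold lower number from compound 2 to compound 3 (0.12 log units; within the scatter) and so stays small. Compound 3 is expected at 5000 nM with 2500 nM to 10000 nM as the estimated range.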

Compound 3, half-maximal inhibitory concentration: 1230 nM
The estimate for compound 3 lay 4.1-fold (0.61 log units) above the measured number; the measured number lies below the stated range.
By their numbers in this assay, from the lowest: compound 3; then compounds 1 and 2 (each within the scatter of the next).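

In this assay, the position on a saturated chain carbon bound to an oxygen on an aromatic ring proved able to shift the number beyond the scatter, which the earlier step had not shown: 3-fluorophenyl in place of 2-(trifluoromethyl)phenyl gave a 5.3-fold lower number from compound 2 to compound 3 (0.73 log units; beyond the scatter). The same group in place of vinyl gave a 2.8-fold lower number from compound 1 to compound 3 (0.45 log units; beyond the scatter), so 3-fluorophenyl is separated from both earlier groups, although those two could not be told apart. Nothing measured here accounts for this difference.

Compound 2 and compound 3 differ in both the substituent on the phenyl ring and its place on that ring, so the contribution of each remains unresolved. On these data alone, it also remains open how an unsubstituted benzyl group or an amine would read at this position.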